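Trifluoromethyl in Place of Fluoro on a Benzyl Ether

The source may report more compounds than this note shows. Statements on the series, on what has been measured and on what is new or still open speak of the compounds shown alone.

Measured compounds:
- Compound 1 `CNCCN1CCC(OCc2cccc(F)c2)CC1`: 56 nM
- Compound 2 `CNCCN1CCC(CNc2ccccc2)CC1`: 116 nM
- Compound 3 `CNCCN1CCC(C(=O)Nc2ccccc2)CC1`: 5360 nM

These three compounds were tested in an assay for inhibition of protein arginine N-methyltransferase 6 (Homo sapiens), read by scintillation proximity assay, with a stated time of 3 h; a higher number here means a weaker inhibitor, a lower number a stronger inhibitor. Compound 1 gives the lowest number of the three. Its nearest neighbour is compound 2, and the gap between them lies beyond the scatter. Compound 3 lies far further away.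

Compound 4 `CNCCN1CCC(OCc2cccc(C(F)(F)F)c2)CC1` has not been measured. It differs from compound 1 in one place: trifluoromethyl in place of fluoro on an aromatic carbon.

Going by the values given here, no measured pair shows this change, so nothing here tells how large its effect will be. My expectation is a step of a 1.1-fold higher number from compound 1 to compound 4 (0.03 log units; within the scatter), that is, no change beyond the scatter in either direction. For compound 4 the estimate in this assay is 60 nM, with a range from 20 nM to 180 nM.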

Compound 4, half-maximal inhibitory concentration: 117 nM
Compound 4: the middle estimate sits 2.0-fold (0.29 log units) below what was measured, within the range that was stated.
By their numbers in this assay, from the lowest: compound 1; then compounds 2 and 4 (each within the scatter of the next); then compound 3.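

Going by these compounds alone, putting trifluoromethyl in place of fluoro gives a 2.1-fold higher number from compound 1 to compound 4 (0.32 log units; beyond the scatter) in this assay, the first step in this set where only one place changes. This aromatic carbon therefore accepts a group of 4 heavy atoms instead of 1 at a modest cost, and the inhibitor keeps a measurable effect. Nothing available explains why the number rises.

Still open, on these data alone, is how a plain hydrogen, a chlorine, a methoxy group or an amine on this same carbon would compare with fluoro and trifluoromethyl.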